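Isopropoxy for carboxyethyl on a benzamide series

The source may report more compounds than this note shows. Statements on the series, on what has been measured and on what is new or still open speak of the compounds shown alone.

Measured so far in an assay on HeLa cells with Bile acid receptor (Homo sapiens) as the target, read by a luciferase reporter, with a stated time of 24 h; on this read-out higher numbers stand for an effect only at larger amounts of compound and lower numbers for an effect already at smaller amounts:
compound 1 `CC(C)(C)c1ccc(C(=O)NCc2ccc(S(N)(=O)=O)cc2)cc1`: 1400 nM
compound 2 `CC(=O)c1ccc(CNC(=O)c2ccc(C(C)(C)C)cc2)cc1`: 100 nM
compound 3 `CC(C)(C)c1ccc(C(=O)NCc2ccc(CCC(=O)O)cc2)cc1`: 350 nM

Compound 3 stands second highest of the three numbers in this assay. Its nearest neighbour is compound 2, reached by a 3.5-fold higher number from compound 2 to compound 3 (0.54 log units; beyond the scatter); the furthest is compound 1, from which it is separated by a 4.0-fold lower number from compound 1 to compound 3 (0.60 log units; beyond the scatter). Both steps are beyond the scatter.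

Compound 4 `CC(C)Oc1ccc(CNC(=O)c2ccc(C(C)(C)C)cc2)cc1` differs from compound 3 in one place: isopropoxy in place of 2-carboxyethyl on an aromatic carbon.

The two steps that bear on this change are those into compound 3. Both are modest: a 4.0-fold lower number from compound 1 to compound 3 (0.60 log units; beyond the scatter) and a 3.5-fold higher number from compound 2 to compound 3 (0.54 log units; beyond the scatter). The group that enters counts one acceptor and no donor, like acetyl in compound 2, whereas the group that leaves counts one donor and one acceptor. On these three compounds, the partner without a donor gives the lowest number, but only compound 2 shows this, so the support is thin.

A modest step downward is therefore expected, a 1.8-fold lower number from compound 3 to compound 4 (0.24 log units; within the scatter), with the range kept wide. The estimate for compound 4 in this assay is 200 nM, between 60 nM and 700 nM.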

Compound 4, half-maximal effective concentration: 170 nM
Estimate against measurement, compound 4: 1.2-fold (0.07 log units) above; measured number inside the range.
By their numbers in this assay, from the lowest: compounds 2 and 4 (each within the scatter of the next); then compound 3; then compound 1.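

Notes on the position para to a large group: in this assay, isopropoxy replacing 2-carboxyethyl gives a 2.1-fold lower number from compound 3 to compound 4 (0.31 log units; beyond the scatter), so a second group without a hydrogen-bond donor now sits lower than compound 3, where previously only the acetyl of compound 2 showed this. Against that acetyl, the change gives a 1.7-fold higher number from compound 2 to compound 4 (0.23 log units; within the scatter), so acetyl and isopropoxy cannot be separated here even though one has a double bond outside the aromatic rings and the other an ether oxygen, while the comparison with sulfamoyl gives an 8.2-fold lower number from compound 1 to compound 4 (0.92 log units; beyond the scatter) and leaves compound 1 with the highest number of the four. No measurement shown here explains any of these differences.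

The shared core still offers only four groups at this position, so the link between the absence of a donor and a lower number rests on compounds 2 and 4 alone. Going by these compounds, it remains open how an amine would compare with isopropoxy at the same carbon, and whether a longer ether chain or a smaller methoxy would hold the number near that of compound 4.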